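This account rests on a few compounds, and the source may have more. Where it says the series, first, only, none or still open, it means among the compounds named here.

Compound 1 `C[C@@H]1CN([C@@H](C)CO)C(=O)c2cccc(NC(=O)NCc3cccc4ccccc34)c2O[C@H]1CN(C)S(=O)(=O)c1ccc2c(c1)OCCO2` stands at the lowest of the two numbers measured in a physicochemical assay for solubility, read by HPLC, in phosphate buffer, measured as thermodynamic solubility, with a stated time of 24 h, at pH 7.4 (a lower number here means a less soluble compound, a higher number a more soluble compound), where compound 1 gives 100 nM. Its nearest measured neighbour is compound 2 `C[C@@H]1CN([C@@H](C)CO)C(=O)c2cccc(NC(=O)Nc3cccc4ncccc34)c2O[C@H]1CN(C)S(=O)(=O)c1ccc2c(c1)OCCO2`, which in this assay reaches 139000 nM, a step of a 1400-fold higher number from compound 1 to compound 2 (3.14 log units; beyond the scatter). Compound 3 `C[C@@H]1CN([C@@H](C)CO)C(=O)c2cccc(NC(=O)Nc3cccc4cnccc34)c2O[C@H]1CN(C)S(=O)(=O)c1ccc2c(c1)OCCO2` differs from compound 1 by isoquinolin-5-yl in place of (naphthalen-1-yl)methyl on an amide-type nitrogen. Within the data shown here, that change closely resembles the one measured between compound 1 and compound 2, so a similarly large upward step is expected, a 1000-fold higher number from compound 1 to compound 3 (3.00 log units; beyond the scatter). Compound 3 is therefore estimated at 100000 nM, with a range from 20000 nM to 500000 nM.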

Compound 3, solubility: 60500 nM
The estimate for compound 3 lay 1.7-fold (0.22 log units) above the measured number; the measured number falls inside the stated range.
By their numbers in this assay, from the lowest: compound 1; then compound 3; then compound 2.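

In this assay the large rise does not belong to quinolin-5-yl alone: isoquinolin-5-yl in place of (naphthalen-1-yl)methyl also gives a 610-fold higher number from compound 1 to compound 3 (2.78 log units; beyond the scatter) on this amide-type nitrogen. Isoquinolin-5-yl in place of quinolin-5-yl gives a 2.3-fold lower number from compound 2 to compound 3 (0.36 log units; beyond the scatter), so the choice between these two groups counts, but far less than leaving (naphthalen-1-yl)methyl. Nothing available explains either step.

Both large steps change the ring atoms and remove the methyl link together, so their shares stay unseparated. A plain naphthalen-1-yl group on this nitrogen would divide them.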